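The compounds below may be only part of what the source reports. "The series", "measured", "known", "first", "only" and "open" are said of these compounds alone.

In a functional assay, read by spectrophotometry, with a stated time of 6 min (a higher number here means a weaker inhibitor, a lower number a stronger inhibitor), compound 1 `CCOc1cc(OC)c(Br)cc1C(C)=O` gives 36000000 nM and stands level with two relatives that carry longer chains on the same oxygen. Compound 2 `CCCCOc1cc(OC)c(Br)cc1C(C)=O` gives 34100000 nM and compound 3 `CCCCCCOc1cc(OC)c(Br)cc1C(C)=O` gives 35700000 nM with no gap beyond the scatter among the three. Not yet measured is compound 4 `CCOc1cc(OC)ccc1C(C)=O` which keeps the ethoxy group of compound 1 and differs from it at one place only. The change (hydrogen in place of bromo on an aromatic carbon) puts hydrogen in place of bromo on an aromatic carbon.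

The three measured steps all lie in the chain on that oxygen. The first is a 1.1-fold lower number from compound 1 to compound 2 (0.02 log units; within the scatter) and the second is a 1.0-fold lower number from compound 1 to compound 3 (0.00 log units; within the scatter) and the third is a 1.0-fold higher number from compound 2 to compound 3 (0.02 log units; within the scatter) with each one small. They show only that chain length among these three compounds leaves the number within the scatter. Among the compounds with values here, none of them touches the bromo, and no measured compound lacks it, so the data give neither a size nor a direction for this change. The expectation is therefore no step beyond the scatter, held with a wide margin. The estimated step is a 1.2-fold higher number from compound 1 to compound 4 (0.07 log units; within the scatter) and no more than that is claimed. Compound 4 is expected at 42000000 nM with an estimated range from 14000000 nM to 110000000 nM until it is measured.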

Compound 4, half-maximal inhibitory concentration: 37700000 nM
Estimate against measurement, compound 4: 1.1-fold (0.05 log units) above; low and high end bracket the measured number.
By their numbers in this assay, from the lowest: compounds 2, 3, 1 and 4 (each within the scatter of the next).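

In this assay, putting hydrogen in place of bromo on the aromatic carbon ortho to a methoxy group, meta to an acetyl group and para to an ethoxy group gives a 1.0-fold higher number from compound 1 to compound 4 (0.02 log units; within the scatter). The earlier compounds shown here all carried the bromo and so could say nothing about it; this step shows that, with the ethoxy group in place, losing that one bromine atom leaves the number within the scatter, just as the changes in chain length on the oxygen did. No available evidence accounts for this lack of effect at the position.

Whether another group at this carbon, such as an amine, a carboxylic acid or a longer chain, would move the number remains open, since the compounds shown carry only bromo or hydrogen there. All four compounds also keep the methoxy and acetyl groups, so what replacing either of these with, for example, a hydroxyl group or a carboxylic acid would do is equally unknown, as is whether hydrogen in place of bromo would give the same result with the butoxy or hexyloxy chains of compounds 2 and 3.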